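Extending the chain on the thiourea nitrogen: compound 2 to compound 3

This account rests on a few compounds, and the source may have more. Where it says the series, first, only, none or still open, it means among the compounds named here.

Measured so far:
compound 1, `CNC(=S)N1N=C(c2ccc(C)cc2)CC1c1ccc[nH]1`: 18.6%
compound 2, `CCNC(=S)N1N=C(c2ccc(C)cc2)CC1c1ccc[nH]1`: 15.4%

In a functional assay on the whole organism (strain Swiss Albino) for inhibition, with Mus musculus as the target, at a dose of 100 mg/kg by the oral route (a lower number here means less inhibition, a higher number more inhibition at the dose given (going by the name of the read-out)), compound 1 gives 18.6%. Compound 2 is the lowest of the two numbers in this assay, where compound 2 gives 15.4%; its nearest neighbour is compound 1, and the step of a number 3.2 percentage points lower from compound 1 to compound 2 (within the scatter) is within the scatter, so the two compounds cannot be told apart on these numbers.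

Compound 3, `CCCNC(=S)N1N=C(c2ccc(C)cc2)CC1c1ccc[nH]1`, has not yet been measured in this assay. It differs from compound 2 by methyl in place of hydrogen on a saturated chain carbon, two bonds along the chain from an amide-type nitrogen. For the measured compounds named here, the only measured step that bears on this change is a number 3.2 percentage points lower from compound 1 to compound 2 (within the scatter), which added the same kind of group one bond closer to the amide-type nitrogen and stayed within the scatter. On that single step, no movement beyond the scatter is expected for compound 3, and the estimated step is a number 1.4 percentage points lower from compound 2 to compound 3 (within the scatter). Compound 3 is therefore expected to give about 14% in this assay, with a range from 4% to 26%.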

Compound 3, a percentage reported as inhibition, in the whole organism at one dose (the size of the read-out at that dose, not a potency): 48.2%
Compound 3: the middle estimate sits 34.2 percentage points below what was measured; the whole stated range lies below it.
By their numbers in this assay, from the lowest: compounds 2 and 1 (each within the scatter of the next); then compound 3.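

In this assay, the saturated chain carbon two bonds along the chain from an amide-type nitrogen proves sensitive to methyl in place of hydrogen, the ethyl to propyl change giving a number 32.8 percentage points higher from compound 2 to compound 3 (beyond the scatter), whereas the same kind of addition one bond closer had given only a number 3.2 percentage points lower from compound 1 to compound 2 (within the scatter). Measured against the methyl compound, ethyl in place of hydrogen on the saturated chain carbon bound to the amide-type nitrogen gives a number 29.6 percentage points higher from compound 1 to compound 3 (beyond the scatter), so the propyl chain of compound 3 stands clear of both shorter chains, which cannot be told apart from each other. The change in the read-out therefore does not follow chain length evenly across these three compounds, and nothing available accounts for why it appears at the propyl chain and not at the ethyl chain.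

The compounds shown leave open whether a longer chain, such as butyl or pentyl, would hold, extend or lose this higher number, and whether a branched chain such as isopropyl would behave like the propyl chain. They also leave open whether a hydroxyl or an amine at the end of the propyl chain would keep the effect, and how compound 3 would read at doses other than the single one given.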